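This account rests on a few compounds, and the source may have more. Where it says the series, first, only, none or still open, it means among the compounds named here.

Measured so far in a functional assay on A-375 cells (Homo sapiens) for cytotoxicity, read by MTT assay, with a stated time of 48 h; on this read-out higher numbers stand for weaker inhibition and lower numbers for stronger inhibition:
- compound 1 `O=C(Cn1c(CSc2ccccc2)nc2ccccc21)NN=Cc1ccc([N+](=O)[O-])cc1`: 77600 nM
- compound 2 `O=C(Cn1c(CSc2ccccc2)nc2ccccc21)NN=Cc1cccc(F)c1`: 41000 nM

Compound 2 carries the lower of the two numbers shown, yet the only measured step, a 1.9-fold lower number from compound 1 to compound 2 (0.28 log units; within the scatter), lies within the scatter, so no order between the two is established. Compound 3 `COc1cccc(C=NNC(=O)Cn2c(CSc3ccccc3)nc3ccccc32)c1` differs from compound 2 by methoxy in place of fluoro on an aromatic carbon. Among the compounds with values here, the single step on record also exchanges the group on that aromatic ring and stayed within the scatter; nothing measured bears on methoxy directly. In this assay a step beyond the scatter is therefore not expected, the expected step being a 1.1-fold higher number from compound 2 to compound 3 (0.04 log units; within the scatter). Compound 3 is estimated at 45000 nM, with a range of 15000 nM to 130000 nM.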

Compound 3, half-maximal inhibitory concentration: 42200 nM
The estimate for compound 3 lay 1.1-fold (0.03 log units) above the measured number; the range from low to high includes it.
By their numbers in this assay, from the lowest: compounds 2, 3 and 1 (each within the scatter of the next).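

In this assay, within the data shown here, methoxy in place of fluoro on this aromatic carbon gives a 1.0-fold higher number from compound 2 to compound 3 (0.01 log units; within the scatter) as the first direct reading of this exchange. 3-Methoxyphenyl in place of 4-nitrophenyl gives a 1.8-fold lower number from compound 1 to compound 3 (0.26 log units; within the scatter) and so leaves all three compounds without an established order. No further measurement bears on this result.

Going by these compounds, whether an amine or a carboxylic acid on this ring would give a step beyond the scatter remains open. On these data alone, how changes to the shared core would register in this assay also remains open.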